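The source may hold more compounds than are shown below. What is called first, only, known or untested is meant among the compounds shown, and "the series" means these compounds.

In a functional assay on CCRF-CEM cells (Homo sapiens) for antiproliferative activity, with a stated time of 72 h (a higher number here means a weaker inhibitor, a lower number a stronger inhibitor), compound 1 `OC[C@H]1O[C@@H](n2cnc3c(NCc4ccccc4F)ncnc32)[C@H](O)[C@@H]1O` gives 4600 nM, compound 2 `OC[C@H]1O[C@@H](n2cnc3c(NCc4ccc(Cl)cc4)ncnc32)[C@H](O)[C@@H]1O` gives 10200 nM and compound 3 `OC[C@H]1O[C@@H](n2cnc3c(NCc4ccccc4Br)ncnc32)[C@H](O)[C@@H]1O` gives 12300 nM. Compound 3 stands high on these numbers: there is a 1.2-fold higher number from compound 2 to compound 3 (0.08 log units; within the scatter), but a 2.7-fold higher number from compound 1 to compound 3 (0.43 log units; beyond the scatter). Compound 4 `OC[C@H]1O[C@@H](n2cnc3c(NCc4ccc(Cl)c(Cl)c4)ncnc32)[C@H](O)[C@@H]1O` changes only the aromatic group on the shared core: 3,4-dichlorophenyl in place of 2-bromophenyl on a saturated chain carbon bound to a nitrogen on an aromatic ring. The other measured changes of this group are also small, with a 2.2-fold higher number from compound 1 to compound 2 (0.35 log units; beyond the scatter). Compound 2 also carries chlorine, and its value is not separated from that of compound 3, so no large shift is expected in this assay. The expected change is a 1.4-fold lower number from compound 3 to compound 4 (0.14 log units; within the scatter), probably within the scatter. For compound 4 the estimate is 9000 nM, with an expected range from 3500 nM to 22000 nM.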

Compound 4, half-maximal inhibitory concentration: 3800 nM
Estimate against measurement, compound 4: 2.4-fold (0.37 log units) above; the measured number falls inside the stated range.
By their numbers in this assay, from the lowest: compounds 4 and 1 (each within the scatter of the next); then compounds 2 and 3 (each within the scatter of the next).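

In this assay, the earlier changes to this aromatic group only raised the number from compound 1, whereas this change lowers it: there is a 3.2-fold lower number from compound 3 to compound 4 (0.51 log units; beyond the scatter). Adding one chlorine alone is enough for a clear shift, with a 2.7-fold lower number from compound 2 to compound 4 (0.43 log units; beyond the scatter), while the 3,4-dichlorophenyl and 2-fluorophenyl groups cannot be told apart, with a 1.2-fold lower number from compound 1 to compound 4 (0.08 log units; within the scatter). Nothing available gives a cause for these shifts. As far as these compounds go, it remains open whether the added chlorine would have the same effect on its own, without the chlorine already present in compound 2. From the compounds shown here alone, how a methoxy group or an amine on this ring would behave also remains open.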